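The source may report more compounds than this note shows. Statements on the series, on what has been measured and on what is new or still open speak of the compounds shown alone.

Compound 1 `CCc1cccc2c(OC)c(-c3occ(C)c3COC)ccc12`: > 10 ug/mL
Compound 2 `CCc1cccc2c(OC)c(-c3occ(C)c3COC(C)=O)ccc12`: > 10 ug/mL
Compound 3 `CCOc1c(-c2occ(C)c2COC)ccc2c(CC)cccc12`: > 10 ug/mL

Going by the values given here, in a functional assay on A549 cells (Homo sapiens) for cytotoxicity, read by MTT assay, with a stated time of 72 h (a higher number here means that more compound is needed for the effect, a lower number that less compound is needed), every value so far is a limit of the assay and not a number, all three sitting at the limit of > 10 ug/mL in this assay, at which 3 of the 3 values shown sit. From compound 1 to compound 2 the change is acetyl in place of methyl on an oxygen on a saturated carbon, and the step that the two limits leave unreadable from compound 1 to compound 2 cannot be read because both ends are limits. The core of compound 3 differs from that of compound 1 by methyl in place of hydrogen on a saturated chain carbon bound to an oxygen on an aromatic ring. Compound 4 `CCOc1c(-c2occ(C)c2COC(C)=O)ccc2c(CC)cccc12` is not yet measured; it differs from compound 3 by acetyl in place of methyl on an oxygen on a saturated carbon, the same change as from compound 1 to compound 2, at a place described in the same words. Given that compound 3 sits at > 10 ug/mL and the earlier step that the two limits leave unreadable from compound 1 to compound 2 showed nothing readable, the expected step that the limit leaves unreadable from compound 3 to compound 4 is flat, most likely again a limit. The estimate for compound 4 is 15 ug/mL.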

Compound 4, concentration for half-maximal effect: > 10 ug/mL
Compound 4: only a limit was reported; the forecaster's own chance of this, stated with the estimate: 85%; the middle value does not contradict the limit.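

Compound 4 is again only a limit, so the steps from compound 3 to compound 4 and from compound 2 to compound 4 cannot be read: the limit of > 10 ug/mL in this assay, at which 4 of the 4 values shown sit. The compounds shown leave open whether either change has any size in this assay.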